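This account rests on a few compounds, and the source may have more. Where it says the series, first, only, none or still open, it means among the compounds named here.

In an assay on CHO-TREX cells for antagonist activity at transient receptor potential cation channel subfamily A member 1 (Homo sapiens), read by FLIPR and calcium flux, with a stated time of 10 min (a lower number here means a stronger inhibitor, a higher number a weaker inhibitor), three compounds have been measured so far.

Compound 1 `c1ccc(-c2ccc3[nH]ncc3c2)cc1` is reported only as > 30000 nM, which is a limit of the assay and not a number.
Compound 2 `CCc1ccccc1-c1ccc2[nH]ncc2c1` gives 584 nM.
Compound 3 `CC(C)c1cc2[nH]ncc2cc1-c1ccccc1C(F)(F)F` gives 25400 nM.

Among the two actual numbers, compound 3 stands at the high end, that is, as the weaker inhibitor of the two; compound 2 is its nearest neighbour, and the gap between them lies well beyond the usual scatter of this assay.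

The next compound, compound 4 `N#Cc1cc2[nH]ncc2cc1-c1ccccc1C(F)(F)F`, differs from compound 3 in one place: cyano in place of isopropyl on an aromatic carbon. Among the measured compounds shown here, only one step between measured compounds is available, an at least 51-fold lower number from compound 1 to compound 2 (1.71 log units; beyond the scatter), and that step concerns a different group at a different place, so it gives no direct guide to an exchange of isopropyl for cyano. What it does show is that a single small change on an aromatic carbon can move the result a long way in this assay. For the measured compounds named here, with no closer precedent, the expectation for compound 4 is a modest step downward, a 3.2-fold lower number from compound 3 to compound 4 (0.50 log units; beyond the scatter), toward stronger inhibition, but with wide uncertainty. The estimate for compound 4 is 8000 nM, within a range from 1500 nM to 40000 nM.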

Compound 4, half-maximal inhibitory concentration: 129 nM
Compound 4: middle estimate off by 62-fold (1.79 log units), on the high side; measured number below the stated range.
By their numbers in this assay, from the lowest: compound 4; then compound 2; then compound 3. At a limit, above all of these: compound 1.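

In this assay the exchange of isopropyl for cyano on this aromatic carbon gives a 200-fold lower number from compound 3 to compound 4 (2.29 log units; beyond the scatter) and so turns a weak inhibitor into a strong one. Among the compounds shown here, the only earlier step concerned a different place, so this is the first sign that this carbon, ortho to a large group and para to a fused ring, also has a strong hold on the result, with the rest of the molecule unchanged. The swap looks small on paper, with isopropyl (3 heavy atoms, 0 hydrogen-bond acceptors) leaving and cyano (2 heavy atoms, 1 hydrogen-bond acceptor) entering, and nothing measured here says which of these differences matters or why the number falls so far.

The compounds shown leave open whether other groups at this place, such as a chlorine atom, a methoxy group, an amine or a carboxylic acid, would also give a low number, so the gain cannot yet be tied to any single feature of cyano. They also leave open whether cyano would have the same effect if the trifluoromethyl group on the other ring were replaced by another group, such as ethyl.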